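Two Substituents Measured, a Third Awaits

The source may hold more compounds than are shown below. What is called first, only, known or untested is meant among the compounds shown, and "the series" means these compounds.

Measured so far:
Compound 1, `Cc1cccc(-c2onc3ccc(C(=O)O)cc23)c1`, gives 1410 nM.
Compound 2, `O=C(O)c1ccc2noc(-c3cccc(C(F)(F)F)c3)c2c1`, gives 4620 nM.

Both numbers come from an assay for inhibition of inositol hexakisphosphate kinase 3 (Homo sapiens), read by colorimetric assay, coupled enzyme assay and malachite green, with a stated time of 120 min, in the presence of a further agent that is not named here; a lower number here means a stronger inhibitor, a higher number a weaker inhibitor. Among the two measured compounds, compound 2 stands with the highest number; its only neighbour, compound 1, sits lower, as told by a 3.3-fold higher number from compound 1 to compound 2 (0.52 log units; beyond the scatter).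

Compound 3, `O=C(O)c1ccc2noc(-c3cccc(-c4ccccc4)c3)c2c1`, has not yet been measured. It differs from compound 2 in one place: phenyl in place of trifluoromethyl on an aromatic carbon.

Among the compounds with values here, only one measured step bears on this change, and only indirectly. The step from methyl to trifluoromethyl, a 3.3-fold higher number from compound 1 to compound 2 (0.52 log units; beyond the scatter), shows that swapping the group at this position can shift the number by a modest but real amount. Within the data shown here, no measured step shows what a phenyl does there. The expectation is therefore cautious: a step from compound 2 to compound 3 of a 1.5-fold lower number from compound 2 to compound 3 (0.19 log units; within the scatter), with no firm direction, and a wide range to match the lack of direct precedent.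

Compound 3 is estimated at 3000 nM, expected to lie between 700 nM and 13000 nM.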

Compound 3, half-maximal inhibitory concentration: 840 nM
For compound 3 the middle estimate is 3.6-fold (0.55 log units) above the measured one; low and high end bracket the measured number.
By their numbers in this assay, from the lowest: compounds 3 and 1 (each within the scatter of the next); then compound 2.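

In this assay, this position turns out to accept a whole aromatic ring, which neither methyl nor trifluoromethyl could show, since neither group has a ring: phenyl in place of trifluoromethyl gives a 5.5-fold lower number from compound 2 to compound 3 (0.74 log units; beyond the scatter), a step beyond the usual scatter and the largest seen so far among these compounds. Set against methyl, the same ring gives a 1.7-fold lower number from compound 1 to compound 3 (0.22 log units; within the scatter), which lies within the scatter, so compound 3 and compound 1 cannot be told apart here, and only compound 2, with its trifluoromethyl, stands apart from both. Nothing measured alongside these numbers explains why trifluoromethyl differs from the other two groups.

The compounds shown leave open whether the added ring can itself carry further groups, such as an amine or a methoxy group, and whether a non-aromatic ring such as cyclohexyl or a longer chain such as butyl would fit as well as phenyl does. They also leave open whether phenyl would give a similar number at another carbon of the same ring.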